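Trifluoromethyl in place of cyano on an aromatic carbon

A few compounds are considered here, and "the series" means these few. Any claim that something is new, unique, unknown or untested is made for them only; others in the source may bear on it.

In an ADME assay on CHO cells (Cricetulus griseus) for inhibition, read by MTT assay (on this read-out higher numbers stand for weaker inhibition and lower numbers for stronger inhibition), compound 1 (`CCN(CC)Cc1cccc(Nc2nc3ccccc3n2Cc2ccc(F)cc2)c1O`) gives > 50000 nM, which is a limit of the assay and not a number. Going by the values given here, compound 2 (`CCN(CC)Cc1ccc(Nc2nc3ccccc3n2Cc2ccc(C#N)cc2)cc1O`) gives 39000 nM, the only true number so far. Compound 3 (`CCN(CC)Cc1ccc(Nc2nc3ccccc3n2Cc2ccc(C(F)(F)F)cc2)cc1O`) carries trifluoromethyl in place of cyano on an aromatic carbon, para to a large group: trifluoromethyl in place of cyano on an aromatic carbon. Among the compounds with values here, no measured pair shows what this exchange does in this assay, since compound 1 and compound 2 differ in more than one place. No change beyond the usual scatter is therefore expected, with only a slight lean towards stronger inhibition. The estimated step of a 1.3-fold lower number from compound 2 to compound 3 (0.11 log units; within the scatter) stays within that scatter. With compound 2 at 39000 nM as the only numerical anchor, compound 3 is estimated at 30000 nM, with an expected range from 12000 nM to 60000 nM.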

Compound 3, half-maximal inhibitory concentration: 41500 nM
For compound 3 the middle estimate is 1.4-fold (0.14 log units) below the measured one; measured number inside the range.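

In this assay, going by these compounds alone, trifluoromethyl in place of cyano gives the only step that can be read so far: a 1.1-fold higher number from compound 2 to compound 3 (0.03 log units; within the scatter). At this place, para to a large group, the read-out therefore does not tell the two groups apart, even though trifluoromethyl has more heavy atoms and no hydrogen-bond acceptor, while cyano has one. Compound 1 stands at a limit of the assay and not at a number: the limit of > 50000 nM in this assay, at which 1 of the 3 values shown sits.

From the compounds shown here alone, it remains open whether a group of another kind at this place, such as an amine or a carboxylic acid, would shift the number beyond the scatter. Compound 1 differs from compound 2 and compound 3 in more than one place, so what the other parts of the molecule contribute cannot be read.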